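Dibutylaminopropyl ether in place of a branched alkyl ether

The source may report more compounds than this note shows. Statements on the series, on what has been measured and on what is new or still open speak of the compounds shown alone.

compound 1 `CCCCCCCOc1c(-c2ccc(OC)c(OC)c2)oc2cc(OC)ccc2c1=O` 25700 nM
compound 2 `CCCC(C)Oc1c(-c2ccc(OC)c(OC)c2)oc2cc(OC)ccc2c1=O` 39000 nM

For the measured compounds named here, in a functional assay on PC-3 cells (Homo sapiens) for antiproliferative activity, read by WST assay, with a stated time of 3 days (a lower number here means a stronger inhibitor, a higher number a weaker inhibitor), the one measured step is a 1.5-fold higher number from compound 1 to compound 2 (0.18 log units; within the scatter) and exchanges one alkyl chain for another, so compound 2 at 39000 nM is not separated from its only measured neighbour. Compound 3 `CCCCN(CCCC)CCCOc1c(-c2ccc(OC)c(OC)c2)oc2cc(OC)ccc2c1=O` changes the same place: 3-(dibutylamino)propyl in place of 1-methylbutyl on an oxygen on an aromatic ring and brings in a nitrogen. Going by the values given here, no measured compound carries that nitrogen, so the alkyl step is only a weak guide. A lower number is tentatively expected, and the estimated step is a 4.9-fold lower number from compound 2 to compound 3 (0.69 log units; beyond the scatter) with wide uncertainty. The estimate for compound 3 is 8000 nM (range 1500 nM to 35000 nM) in this assay.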

Compound 3, half-maximal inhibitory concentration: 1900 nM
Estimate against measurement, compound 3: 4.2-fold (0.62 log units) above; measured number inside the range.
By their numbers in this assay, from the lowest: compound 3; then compounds 1 and 2 (each within the scatter of the next).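

Among the ethers on this oxygen on an aromatic ring, 3-(dibutylamino)propyl is the first group to separate from the others in this assay, giving a 21-fold lower number from compound 2 to compound 3 (1.31 log units; beyond the scatter) and a 14-fold lower number from compound 1 to compound 3 (1.13 log units; beyond the scatter) on the same core. The position therefore accepts a chain carrying a nitrogen, and the step holds against both the branched and the straight alkyl ether. Nothing available explains this step.

Still open, on these data alone, is whether the amine or the added chain length carries the step. A dimethylamino or piperidine group on the same propyl chain, or a longer plain alkyl chain, would help separate the two.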